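The compounds below may be only part of what the source reports. "The series", "measured", "known", "first", "only" and "open" are said of these compounds alone.

Two compounds have so far been run through an assay on isolated protein for binding affinity to 5-hydroxytryptamine receptor 1B (Homo sapiens); a lower number here means a stronger inhibitor, a higher number a weaker inhibitor. Compound 1 `COc1cc2c(cc1N1C[C@@H](C)N(C)[C@@H](C)C1)N(C(=O)c1ccc(-c3cccc(C)n3)c3ccccc13)CC2` gives 3.16 nM in this assay. Compound 2 `COc1cc2c(cc1N1C[C@@H](C)N[C@@H](C)C1)N(C(=O)c1ccc(-c3ccc(-c4ncccn4)cc3C)cc1)CC2` gives 5.01 nM in this assay. For the measured compounds named here, of these two numbers compound 2 carries the higher one, but its only neighbour is compound 1, and the gap between the two lies within the scatter, so the two cannot be placed in any order of strength. Going by the values given here, no measured pair differs in a single place, so nothing measured shows how one change of a group moves the number. Compound 3 `COc1cc2c(cc1N1C[C@@H](C)N[C@@H](C)C1)N(C(=O)c1ccc(-c3ccc(C(C)=O)cc3C)cc1)CC2` differs from compound 2 in one place: acetyl in place of pyrimidin-2-yl on an aromatic carbon. Among the compounds with values here, the data hold no measured step for a change of this kind, so the expectation rests on the change itself. A small step is expected, a 1.3-fold higher number from compound 2 to compound 3 (0.10 log units; within the scatter), in the direction of a slightly higher number and not beyond the scatter. Compound 3 is therefore estimated at 6.3 nM in this assay, with a range from 2.5 nM to 16 nM.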

Compound 3, inhibition constant: 3.16 nM
Beside the measured number, compound 3's estimate is 2.0-fold (0.30 log units) above it; the measured number falls inside the stated range.
By their numbers in this assay, from the lowest: compounds 1, 3 and 2 (each within the scatter of the next).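

For the compounds shown here, exchanging pyrimidin-2-yl for acetyl on the aromatic carbon that lies meta to a methyl group and para to a large group gives the first single-place comparison in this assay (a 1.6-fold lower number from compound 2 to compound 3 (0.20 log units; within the scatter)). At this position, a six-membered aromatic ring with 2 hetero atoms and an acetyl group with no ring and only 3 heavy atoms cannot be told apart by their numbers, so in this pair the ring is not needed to keep the value within the scatter of compound 2. The measurements offer no explanation of why this large an exchange of atoms leaves the two numbers so close.

As far as these compounds go, what remains open is whether other groups at this position, such as an amine, a carboxylic acid or a longer alkyl chain, would also stay within the scatter or would move the number beyond it. A single pair also leaves open whether the exchange of pyrimidin-2-yl for acetyl would read the same if the methyl group on that ring were replaced by hydrogen or by chlorine.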